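Bromo for isopropyl on the aryl group

The source may report more compounds than this note shows. Statements on the series, on what has been measured and on what is new or still open speak of the compounds shown alone.

Three compounds of the series carry a shared core with a varied aryl group on an aromatic nitrogen. Compound 1 `Cc1ccc(-n2cc(COc3cccc(NC(=O)Nc4ccc(Cl)c(C(F)(F)F)c4)c3)nn2)cc1` gives 5430 nM in a functional assay on HepG2 cells (Homo sapiens) for inhibition, read by MTT assay, with a stated time of 72 h; on this read-out higher numbers stand for weaker inhibition and lower numbers for stronger inhibition. Compound 2 `CCc1cccc(-n2cc(COc3cccc(NC(=O)Nc4ccc(Cl)c(C(F)(F)F)c4)c3)nn2)c1` gives 37900 nM in this assay, and compound 3 `CC(C)c1ccccc1-n1cc(COc2cccc(NC(=O)Nc3ccc(Cl)c(C(F)(F)F)c3)c2)nn1` gives 1900 nM. Compound 3 stands lowest of the three: a 2.9-fold lower number from compound 1 to compound 3 (0.46 log units; beyond the scatter) and a 20-fold lower number from compound 2 to compound 3 (1.30 log units; beyond the scatter), while a 7.0-fold higher number from compound 1 to compound 2 (0.84 log units; beyond the scatter) runs the other way. Compound 4 `O=C(Nc1cccc(OCc2cn(-c3ccccc3Br)nn2)c1)Nc1ccc(Cl)c(C(F)(F)F)c1` is not yet measured; it differs from compound 3 by bromo in place of isopropyl on an aromatic carbon. No measured step exchanges one group for another on the same aromatic carbon; the three steps shown all replace the whole aryl group, so they bear only indirectly, showing that this aryl group moves the number by modest to large amounts. The estimated step is of uncertain direction and modest at most: a 1.6-fold higher number from compound 3 to compound 4 (0.20 log units; within the scatter). Compound 4 is expected at 3000 nM, between 1000 nM and 10000 nM.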

Compound 4, half-maximal inhibitory concentration: 2810 nM
For compound 4 the middle estimate is 1.1-fold (0.03 log units) above the measured one; measured number inside the range.
By their numbers in this assay, from the lowest: compounds 3, 4 and 1 (each within the scatter of the next, the first and the last beyond it); then compound 2.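

On an aromatic carbon ortho to a large group, bromo in place of isopropyl gives a 1.5-fold higher number from compound 3 to compound 4 (0.17 log units; within the scatter) in this assay, so this first direct exchange at the position shows no change beyond the scatter. The 2-bromophenyl group also stays within the scatter of the 4-methylphenyl group, with a 1.9-fold lower number from compound 1 to compound 4 (0.29 log units; within the scatter), but keeps a large gap to the 3-ethylphenyl group, with a 13-fold lower number from compound 2 to compound 4 (1.13 log units; beyond the scatter). Nothing available here accounts for these results.

Because the aryl steps change group and place together, the effect of place alone remains unresolved, including whether bromo on another carbon of this ring would reproduce the gap seen with the 3-ethylphenyl group. Also open, going by these compounds, is how an amine or a carboxylic acid on the same aromatic carbon would read in this assay.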